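Replacing the nitro group: expected cytotoxicity of compound 3

The compounds below may be only part of what the source reports. "The series", "measured", "known", "first", "only" and "open" are said of these compounds alone.

Measured compounds in an ADME assay on MT4 cells (Homo sapiens) for cytotoxicity, read by MTT assay; on this read-out lower numbers stand for higher toxicity in this test and higher numbers for lower toxicity in this test:
- Compound 1, `O=C(CSc1nnnn1-c1cccc2ccccc12)N/N=C/c1ccccc1F`, gives >= 118000 nM, which is a limit of the assay and not a number.
- Compound 2, `O=C(CSc1nnnn1-c1cccc2ccccc12)N/N=C/c1ccc([N+](=O)[O-])cc1`, gives >= 260000 nM, also a limit of the assay.

Compound 2 therefore stands only at a limit, with no numerical value. The step from compound 1 to compound 2, a step that the two limits leave unreadable from compound 1 to compound 2, cannot be read, since both the limit of >= 118000 nM in this assay, at which 1 of the 2 values shown sits, and the limit of >= 260000 nM in this assay, at which 1 of the 2 values shown sits, are limits rather than numbers. Compound 3, `Cc1cccc(/C=N/NC(=O)CSc2nnnn2-c2cccc3ccccc23)c1`, differs from compound 2 by 3-methylphenyl in place of 4-nitrophenyl on a carbon with a double bond to nitrogen. No readable measured step bears on this change, so its size in this assay cannot be drawn from the data. What the two limits do show is that both measured compounds sit at the high-concentration end of the read-out. For compound 3, the step of an at least 1.3-fold lower number from compound 2 to compound 3 (0.11 log units; that floor lies within the scatter) is expected to be none beyond the scatter, with the result again most likely a limit. The estimate for compound 3 is 200000 nM, in the range 100000 nM to 400000 nM.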

Compound 3, half-maximal cytotoxic concentration: 269000 nM
Compound 3: middle estimate off by 1.3-fold (0.13 log units), on the low side; the range from low to high includes it.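

No new step can be read in this assay: compound 1 and compound 2 each stand only at a limit of the assay, so neither can be sized against compound 3. The compounds shown leave open whether exchanging the 2-fluorophenyl, 4-nitrophenyl and 3-methylphenyl groups changes cytotoxicity at all.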